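A few compounds are considered here, and "the series" means these few. Any claim that something is new, unique, unknown or untested is made for them only; others in the source may bear on it.

Measured so far:
- compound 1 `Cc1cc(NC(=O)CCc2ccc3[nH]c(-c4ccc(Cl)s4)nc3c2)ccc1N1CCOCC1=O`: < 20%
- compound 2 `O=C(CCc1ccc2[nH]c(-c3ccc(Br)s3)nc2c1)NCC1CCN(c2ccncc2)CC1`: < 20%

Compound 1 stands at a limit in an in vivo ADME assay on the whole organism for pharmacokinetics, with Rattus norvegicus as the target (a higher number here means that a larger share of the oral dose reaches the circulation, a lower number that a smaller share of the oral dose reaches the circulation), not at a number. Compound 2 likewise sits at a limit in this assay. Among the measured compounds shown here, both values shown rest on the same floor (the limit of < 20% in this assay, at which 2 of the 2 values shown sit), so no measured step exists between them. Compound 3 `O=C(CCc1ccc2[nH]c(-c3ccc(Cl)s3)nc2c1)Nc1ccc(N2CCOCC2=O)cc1` differs from compound 1 by hydrogen in place of methyl on an aromatic carbon. For the measured compounds named here, no step of this kind has been measured; the expected step from compound 1 to compound 3 is a step that the limit leaves unreadable from compound 1 to compound 3, none beyond the scatter, in either direction. Compound 3 is expected to give about 10% in this assay, between 2% and 25%, most likely again reported as a limit.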

Compound 3, oral bioavailability: < 20%
Compound 3 ended at the assay's limit; the forecaster's own chance of this, stated with the estimate: 70%; the middle value does not contradict the limit.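

No step from compound 1 to compound 3 can be read in this assay, since both stand at a limit: the limit of < 20% in this assay, at which 3 of the 3 values shown sit.

The compounds shown leave open where any of them truly lies within that limit, and whether hydrogen in place of methyl on an aromatic carbon alters oral bioavailability at all.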